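Swapping Acetyl for Ethylsulfonyl: Expected Cytotoxicity

The compounds below may be only part of what the source reports. "The series", "measured", "known", "first", "only" and "open" are said of these compounds alone.

Compound 1 `CCCCN(c1ccnc(Nc2ccc(C#N)cc2)n1)c1c(F)cc(-c2ccc(C#N)cc2)cc1F` gives 211000 nM in an ADME assay on MT4 cells (Homo sapiens) for cytotoxicity, read by MTT assay, with a stated time of 5 days; a higher number here means that more compound is tolerated, a lower number that less compound is tolerated. Compound 2 `N#Cc1ccc(Nc2nccc(N(CCCO)c3c(F)cc(-c4ccc(C#N)cc4)cc3F)n2)cc1` gives 68000 nM. Compound 3 `CC(=O)N(c1ccnc(Nc2ccc(C#N)cc2)n1)c1c(F)cc(-c2ccc(C#N)cc2)cc1F` is reported only as a limit of the assay, > 268000 nM.

Compound 3 therefore stands at the top of the numbers shown, since its value is the limit (the limit of > 268000 nM in this assay, at which 1 of the 3 values shown sits). The steps that reach it, an at least 1.2-fold higher number from compound 1 to compound 3 (0.10 log units; that floor lies within the scatter) and an at least 3.9-fold higher number from compound 2 to compound 3 (0.59 log units; beyond the scatter), both replace a chain on the nitrogen with acetyl. Compound 4 `CCS(=O)(=O)N(c1ccnc(Nc2ccc(C#N)cc2)n1)c1c(F)cc(-c2ccc(C#N)cc2)cc1F` changes that same group: ethylsulfonyl in place of acetyl on a nitrogen on an aromatic ring. Among the compounds with values here, no measured step alters the acetyl itself, so the step of an at least 1.0-fold lower number from compound 3 to compound 4 (0.03 log units; that floor lies within the scatter) is expected to stay within the scatter. Compound 4 is expected to give about 250000 nM, between 100000 nM and 600000 nM, quite possibly again only as a limit.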

Compound 4, half-maximal cytotoxic concentration: > 125000 nM
Compound 4: a limit, no number; the forecaster's own chance of this, stated with the estimate: 50%; the middle value does not contradict the limit.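

On this nitrogen, ethylsulfonyl joins acetyl as a second group whose compound is reported only as a limit, here compound 4: the limit of > 125000 nM in this assay, at which 1 of the 4 values shown sits. Replacing 3-hydroxypropyl with ethylsulfonyl gives an at least 1.8-fold higher number from compound 2 to compound 4 (0.26 log units; that floor lies within the scatter), which is only a floor on the true size. The steps to compound 4 that start from the acetyl and butyl compounds cannot be read.

As far as these compounds go, it remains open how the two limited compounds would rank if both had real numbers. Also open, from the compounds shown here alone, is whether an amine or a carboxylic acid on this nitrogen would give a number in this assay.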